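From cyclohexyl to 3-chlorophenyl on the side chain

The compounds below may be only part of what the source reports. "The series", "measured", "known", "first", "only" and "open" are said of these compounds alone.

Measured in a functional assay (trachea) with Cavia porcellus as the target; a lower number here means a stronger inhibitor, a higher number a weaker inhibitor:
compound 1 `CCn1nc(-c2cccnc2)c2ccccc2c1=O`: 1320 nM
compound 2 `O=c1c2ccccc2c(-c2cccnc2)nn1CC1CCCCC1`: 209 nM

Of these two numbers, compound 2 holds the lower, 209 nM, and is the stronger inhibitor of the pair. Among the measured compounds shown here, only one step has been measured so far. It is a 6.3-fold lower number from compound 1 to compound 2 (0.80 log units; beyond the scatter), with cyclohexyl taking the place of methyl on a saturated chain carbon bound to an aromatic nitrogen. The next compound, compound 3 `O=c1c2ccccc2c(-c2cccnc2)nn1Cc1cccc(Cl)c1`, changes the same place: 3-chlorophenyl in place of cyclohexyl on a saturated chain carbon bound to an aromatic nitrogen. In words, 3-chlorophenyl stands in place of cyclohexyl.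

For the measured compounds named here, the single step, a 6.3-fold lower number from compound 1 to compound 2 (0.80 log units; beyond the scatter), shows that the number in this assay can move with a change at this place. Going by the values given here, it replaced methyl, however, and no measured compound carries an aromatic ring or chlorine there. The data therefore indicate no direction, and no step beyond the scatter is expected in this assay. For compound 3 the estimated value is 180 nM, with an expected range of 50 nM to 650 nM. This estimate means an expected 1.2-fold lower number from compound 2 to compound 3 (0.06 log units; within the scatter).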

Compound 3, half-maximal inhibitory concentration: 4170 nM
Compound 3: the middle estimate sits 23-fold (1.36 log units) below what was measured, and the stated range ends below it.
By their numbers in this assay, from the lowest: compound 2; then compound 1; then compound 3.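

In this assay this place does not simply reward a ring: the change to 3-chlorophenyl gives a 20-fold higher number from compound 2 to compound 3 (1.30 log units; beyond the scatter) and so runs against the earlier step, which went to a lower number. The result also reaches past the starting point, with a 3.2-fold higher number from compound 1 to compound 3 (0.50 log units; beyond the scatter) when 3-chlorophenyl stands in place of methyl on a saturated chain carbon bound to an aromatic nitrogen. Replacing methyl with a six-membered ring can therefore move the number in either direction, depending on which ring enters, and nothing available here accounts for this reversal.

Cyclohexyl and 3-chlorophenyl differ both in the ring and in the chlorine, so the compounds shown cannot say which of the two goes with the higher number, and a plain phenyl at this place would separate them. Also open, as far as these compounds go, is how a piperidine ring or a longer chain ending in cyclohexyl would read in this assay at this same place.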